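A few compounds are considered here, and "the series" means these few. Any claim that something is new, unique, unknown or untested is made for them only; others in the source may bear on it.

Measured so far in a functional assay on the whole organism for inhibition, with Mus musculus as the target, at a dose of 10 mg/kg; on this read-out higher numbers stand for more inhibition at the one dose given (going by the name of the read-out) and lower numbers for less inhibition:
compound 1 `O=C1C=CS(=O)(=O)c2ccccc21` gives 5.5%;
compound 2 `CCCOCC1=CS(=O)(=O)c2ccccc2C1=O` gives 99.9%;
compound 3 `O=C1C(COCCBr)=CS(=O)(=O)c2ccccc21` gives 100%.

Compound 3 holds the highest of the three numbers, though compound 2 sits within the scatter of it; only compound 1, the bare core, lies clearly apart. Two steps place a group on the double-bonded ring carbon of the core of compound 1, and both were large: a number 94.4 percentage points higher from compound 1 to compound 2 (beyond the scatter) and a number 94.5 percentage points higher from compound 1 to compound 3 (beyond the scatter). Going by the values given here, the single step that alters the chain itself, a number 0.1 percentage points higher from compound 2 to compound 3 (within the scatter), stayed within the scatter.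

Compound 4 `O=C1C(CNc2ccccc2)=CS(=O)(=O)c2ccccc21` has not been measured. It differs from compound 3 in this way: anilino in place of 2-bromoethoxy on a saturated chain carbon bound to a double-bonded ring carbon. The change keeps a substituent on the double-bonded ring carbon and exchanges only its outer part, as the earlier chain change did. Among the compounds with values here, exchanging anilino for 2-bromoethoxy is a larger alteration than bromo for methyl, and anilino enters with a hydrogen-bond donor; no measured step tests such a group, so the expectation is less firm. Still, the two large steps speak for a high number: compound 4 is expected to give 93%, with a range from 70% to 100%. This means an expected step of a number 7 percentage points lower from compound 3 to compound 4 (within the scatter).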

Compound 4, a percentage reported as inhibition, in the whole organism at one dose (the size of the read-out at that dose, not a potency): 0%
Beside the measured number, compound 4's estimate is 93 percentage points above it; the whole stated range lies above it.
By their numbers in this assay, from the lowest: compounds 4 and 1 (each within the scatter of the next); then compounds 2 and 3 (each within the scatter of the next).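

In this assay a substituent on the saturated chain carbon bound to a double-bonded ring carbon does not by itself secure a high number: the outer part of that substituent matters, as a number 100 percentage points lower from compound 3 to compound 4 (beyond the scatter) and a number 99.9 percentage points lower from compound 2 to compound 4 (beyond the scatter) show with anilino entering. The earlier exchange of bromo for methyl stayed within the scatter, whereas with anilino the number falls to the level of the bare core, compound 4 at 0% and compound 1 at 5.5% lying within the scatter of each other. No evidence is available that bears on this result.

The compounds shown leave open whether the drop goes with the nitrogen or with the aromatic ring, as anilino brings both at once. A propylamino chain or a phenoxy group on the same saturated chain carbon would separate the two.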